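Working notes on compounds 1 to 4 at a single dose

The compounds below may be only part of what the source reports. "The series", "measured", "known", "first", "only" and "open" are said of these compounds alone.

Measured so far:
compound 1, `Cn1c(-c2ccc(-c3cncnc3)cc2)nnc1C1(c2ccc(Cl)cc2)CCC1` — 46%
compound 2, `CC(=O)Nc1ccc(-c2nnc(C3(c4ccc(Cl)cc4)CCC3)n2C)c(Cl)c1` — 79%
compound 3, `Cn1c(-c2ccccc2)nnc1C1(c2ccc(Cl)cc2)CCC1` — 29%

In a functional assay on the whole organism (strain ICR) for inhibition, with Mus musculus as the target, read by scintillation counting, with a stated time of 4 h, at a dose of 10 mg/kg by the oral route (on this read-out lower numbers stand for less inhibition and higher numbers for more inhibition at the one dose given (going by the name of the read-out)), compound 2 gives 79%, the highest of the three numbers, and its gaps to compound 1 and to compound 3 both lie beyond the scatter. Among the measured compounds shown here, the only step between two compounds that differ in one place is a number 17 percentage points lower from compound 1 to compound 3 (beyond the scatter), a modest loss on removal of a ring substituent.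

Compound 4 is `Cn1c(-c2ccc(C(=O)O)cc2Cl)nnc1C1(c2ccc(Cl)cc2)CCC1`. Against compound 2 the change is carboxy in place of acetamido on an aromatic carbon. For the measured compounds named here, no measured pair exchanges one substituent for another at this position, so the step from compound 1 to compound 3 bears on it only loosely, as a sign that the substituent on this ring matters to the number. The expectation for compound 4 is therefore a downward move, a number 29 percentage points lower from compound 2 to compound 4 (beyond the scatter), but with wide uncertainty. The estimate for compound 4 is 50%, within a range of 25% to 75%.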

Compound 4, a percentage reported as inhibition, in the whole organism at one dose (the size of the read-out at that dose, not a potency): 90%
Compound 4: middle estimate off by 40 percentage points, on the low side, and the stated range ends below it.
By their numbers in this assay, from the lowest: compound 3; then compound 1; then compound 2; then compound 4.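

In this assay, carboxy in place of acetamido, on the aromatic carbon meta to a chloro group and para to a large group, gives a number 11 percentage points higher from compound 2 to compound 4 (beyond the scatter), so at this position the acetamido group is not needed to reach the top of the series. Among the compounds shown here, the earlier compounds showed only that a substituent on this ring can shift the number; this pair is the first exchange of one substituent for another at a single position, between groups with the same count of hydrogen-bond donors and acceptors. Nothing at hand accounts for the rise.

Open, as far as these compounds go, is whether an amine, a nitrile or a methyl ester at this position would hold the number. Also open, from the compounds shown here alone, is whether the number for carboxy holds without the chloro group, and how the order would look at other doses.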